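A few compounds are considered here, and "the series" means these few. Any claim that something is new, unique, unknown or untested is made for them only; others in the source may bear on it.

Measured in a functional assay on MCF7 cells (Homo sapiens) for antiproliferative activity; a lower number here means a stronger inhibitor, a higher number a weaker inhibitor:
- compound 1 `CC(C)=CCc1cc(C(=O)Nc2cc3ccc(OCC4CCCNC4)c(C)c3oc2=O)ccc1O`: 790 nM
- compound 2 `CCN(CC)CCCOc1ccc2cc(NC(=O)c3ccc(O)c(CC=C(C)C)c3)c(=O)oc2c1C`: 6390 nM
- compound 3 `CC(C)=CCc1cc(C(=O)Nc2cc3ccc(OCCCN(C(C)C)C(C)C)c(C)c3oc2=O)ccc1O`: 1310 nM

Compound 3 stands level with compound 1, within the scatter, at a 1.7-fold higher number from compound 1 to compound 3 (0.22 log units; within the scatter). It lies clearly under compound 2, at a 4.9-fold lower number from compound 2 to compound 3 (0.69 log units; beyond the scatter).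

The next compound is compound 4 `COC(=O)CNCCCOc1ccc2cc(NC(=O)c3ccc(O)c(CC=C(C)C)c3)c(=O)oc2c1C`. The change is ((methoxycarbonyl)methyl)amino in place of diisopropylamino on a saturated chain carbon, three bonds along the chain from an oxygen on an aromatic ring.

Among the compounds with values here, the closest precedent is a 4.9-fold lower number from compound 2 to compound 3 (0.69 log units; beyond the scatter), the only measured step that swaps the amino group alone on this chain. It shows that a swap at this place can move the number beyond the scatter. The step of an 8.1-fold higher number from compound 1 to compound 2 (0.91 log units; beyond the scatter) replaces the side chain more widely and also reaches beyond the scatter, so it bears less directly. Within the data shown here, no measured compound carries the entering group, so the direction rests on weak evidence. A modest move towards a higher number is expected, leaving the value nearer compound 2 than the present one, with a wide margin.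

The expected change is a 2.1-fold higher number from compound 3 to compound 4 (0.33 log units; beyond the scatter). For compound 4 the estimated value is 2800 nM, with an expected range of 800 nM to 9000 nM.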

Compound 4, half-maximal inhibitory concentration: 2820 nM
For compound 4 the middle estimate is 1.0-fold (0.00 log units) below the measured one; measured number inside the range.
By their numbers in this assay, from the lowest: compounds 1 and 3 (each within the scatter of the next); then compound 4; then compound 2.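

In this assay, the ((methoxycarbonyl)methyl)amino group on the propyl chain lands inside the span set by the two earlier amino groups at this place, with a 2.2-fold higher number from compound 3 to compound 4 (0.33 log units; beyond the scatter) against diisopropylamino and a 2.3-fold lower number from compound 2 to compound 4 (0.36 log units; beyond the scatter) against diethylamino, so all three amino groups are now separated beyond the scatter. The oxygen atoms and the hydrogen-bond donor of the entering group, neither of which diisopropylamino has, therefore come with a number still lower than that of the diethylamino compound, which widens the range of amino groups seen at this place. Within the data shown here, the piperidin-3-yl side chain holds a clear margin over the new one, a 3.6-fold higher number from compound 1 to compound 4 (0.55 log units; beyond the scatter), and compound 3 remains the only compound with an open-chain amino group level with compound 1.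

A carboxylic acid in place of the methoxycarbonyl, a morpholine on the same propyl chain or a longer chain lie outside the compounds shown, so it stays open whether the methoxycarbonyl group or the hydrogen on the amino nitrogen carries the difference. No measurement on hand bears on why these amino groups rank as they do.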